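Swapping 3-aminopropyl for 1-phenylethyl on a shared core

A few compounds are considered here, and "the series" means these few. Any claim that something is new, unique, unknown or untested is made for them only; others in the source may bear on it.

As far as these compounds go, in a functional assay on HCT-116 cells (Homo sapiens) for cytotoxicity, read by MTT assay, with a stated time of 72 h (a lower number here means a stronger inhibitor, a higher number a weaker inhibitor), compound 1 (`NCCCNc1c(C(=O)NCc2ccc(F)cc2)nc(Br)c2cccnc12`) gives > 20000 nM as a limit and not a number, so its true strength is unknown. Compound 2 (`O=C(NCCCNc1c(C(=O)NCc2ccc(F)cc2)nc(Br)c2cccnc12)c1ccccc1`) gives > 10000 nM as a limit too. The change under study leads to compound 3 (`C[C@H](Nc1c(C(=O)NCc2ccc(F)cc2)nc(Br)c2cccnc12)c1ccccc1`), which carries 1-phenylethyl in place of 3-aminopropyl on a nitrogen on an aromatic ring.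

Among the measured compounds shown here, only one measured step bears on this change. That step (a step that the two limits leave unreadable from compound 1 to compound 2) puts benzoyl in place of hydrogen on an amine nitrogen, at the end of the same 3-aminopropyl chain that compound 3 loses altogether. Its size cannot be read, so it gives no scale to carry over, and any expectation here stays loose. Both measured compounds ended at limits, so only a modest gain in strength is expected, and the estimate for the step (an at least 2.0-fold lower number from compound 1 to compound 3 (0.30 log units; that floor lies within the scatter)) is wide. In this assay the value expected for compound 3 is 10000 nM with a range from 2500 nM to 40000 nM and it may yet return only as a limit.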

Compound 3, half-maximal inhibitory concentration: > 20000 nM
Compound 3: a limit, no number; the forecaster's own chance of this, stated with the estimate: 45%; at least 2.0-fold (0.30 log units) between middle value and limit.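

In this assay, among the compounds shown here, compound 3 ends at a limit and not a number, as compound 1 does, so no step between compound 1 and compound 3 can be read. The compounds shown leave open how strong any of them truly is, and whether 1-phenylethyl or 3-aminopropyl on the shared core gives the lower number.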